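This account rests on a few compounds, and the source may have more. Where it says the series, first, only, none or still open, it means among the compounds named here.

Compound 3, whose structure is `O=[N+]([O-])c1ccc(-c2nnc(-c3ccc(-n4cccc4)cc3)o2)cc1`, carries a nitro group on the shared core of compound 1, `c1ccc(-c2nnc(-c3ccc(-n4cccc4)cc3)o2)cc1`. In an ADME assay on Vero cells (Chlorocebus sabaeus) for cytotoxicity, read by MTT assay, with a stated time of 72 h (a higher number here means a weaker inhibitor, a lower number a stronger inhibitor), compound 3 gives 258000 nM. Compound 1 gives 250000 nM in this assay, and compound 2, `Brc1ccc(-c2nnc(-c3ccc(-n4cccc4)cc3)o2)cc1`, with a bromo group in the same position, gives 260000 nM. The three numbers lie within the scatter of one another, so compound 3 stands indistinguishable from both neighbours: the step of a 1.0-fold higher number from compound 1 to compound 3 (0.01 log units; within the scatter) and the step of a 1.0-fold lower number from compound 2 to compound 3 (0.00 log units; within the scatter) are both within the scatter, as is the step of a 1.0-fold higher number from compound 1 to compound 2 (0.02 log units; within the scatter).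

Compound 4, `Clc1ccc(-c2nnc(-c3ccc(-n4cccc4)cc3)o2)cc1`, differs from compound 3 by the change (chloro in place of nitro on an aromatic carbon). Every substituent so far placed at this position, whether bromo or nitro, or none at all, has left this assay unchanged within the scatter, and the chloro group of compound 4 is a small halogen of the same kind as the bromo of compound 2. The expected step is therefore a 1.0-fold lower number from compound 3 to compound 4 (0.01 log units; within the scatter), that is, none beyond the scatter. Compound 4 is estimated at 255000 nM, with a range from 130000 nM to 500000 nM.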

Compound 4, half-maximal inhibitory concentration: 253000 nM
Beside the measured number, compound 4's estimate is 1.0-fold (0.00 log units) above it, and the stated range covers the measured number.
By their numbers in this assay, from the lowest: compounds 1, 4, 3 and 2 (each within the scatter of the next).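

In this assay the chloro group adds a fourth case at this position, on an aromatic carbon para to a large group: a 1.0-fold higher number from compound 1 to compound 4 (0.01 log units; within the scatter) and a 1.0-fold lower number from compound 2 to compound 4 (0.01 log units; within the scatter) and a 1.0-fold lower number from compound 3 to compound 4 (0.01 log units; within the scatter) are the new steps. A second halogen thus behaves like the first here, and the direct exchange of nitro, which has hydrogen-bond acceptors, for chloro, which has none, also leaves the number within the scatter, so hydrogen, bromo, nitro and chloro cannot be told apart at this position. No measurement given here offers an explanation for this result.

Going by these compounds, whether an amine, a carboxylic acid or a longer chain at this position would stay within the scatter remains open. The compounds shown also leave open whether changes elsewhere on the shared core would move the number in this assay.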